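The compounds below may be only part of what the source reports. "The series", "measured", "known", "first", "only" and "open" are said of these compounds alone.

Of the compounds shown here, three sharing one core have so far been tested in a functional assay on the whole organism (strain albino) for inhibition, with Rattus norvegicus as the target, read by paw edema, with stated times of 30 min and 3 h, at a dose of 100 mg/kg by the oral route; on this read-out lower numbers stand for less inhibition and higher numbers for more inhibition at the one dose given (going by the name of the read-out). For the measured compounds named here, compound 1 `COc1ccc(C2=NNC(c3ccco3)C2)cc1OC` gives 60% in this assay, and compound 3 `COc1ccc(C2=NN(C(=O)CBr)C(c3c(Cl)cccc3Cl)C2)cc1OC`, the only measured compound that carries a carbonyl group bearing a bromine, gives 69%. Compound 2 `COc1ccc(C2CC(c3ccc(OC)c(OC)c3)=NN2)c(OC)c1` gives 42% in this assay, the lowest of the three numbers: the nearest number, that of compound 1, lies higher by more than the usual scatter, and the furthest, that of compound 3, lies higher still, also beyond the scatter.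

Compound 4 `COc1ccc(C2CC(c3ccc(OC)c(OC)c3)=NN2C(=O)C(C)Br)c(OC)c1` has not yet been measured. It differs from compound 2 in a single place: (1-bromoethyl)carbonyl in place of hydrogen on an amine nitrogen in a ring. Going by the values given here, no pair of measured compounds shows this exact change, so the data give no direct guide to the size of the step. A rise is nevertheless expected because compound 3 gives 69%, the highest number among the measured compounds, with a related bromine-bearing carbonyl group. The step expected in this assay is a number 12 percentage points higher from compound 2 to compound 4 (beyond the scatter), a moderate gain that clears the scatter but stays short of certainty. Compound 4 is therefore estimated to give about 54% in this assay, with a likely range from 38% to 70%.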

Compound 4, a percentage reported as inhibition, in the whole organism at one dose (the size of the read-out at that dose, not a potency): 69%
Beside the measured number, compound 4's estimate is 15 percentage points below it, within the range that was stated.
By their numbers in this assay, from the lowest: compound 2; then compounds 1, 3 and 4 (each within the scatter of the next).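

In this assay, the amine nitrogen in the ring of compound 2 proves to be a place where a substituent can raise the number: (1-bromoethyl)carbonyl in place of hydrogen gives a number 27 percentage points higher from compound 2 to compound 4 (beyond the scatter) at the one dose tested. For the compounds shown here, this is the first direct reading of a change at this position, as no earlier pair of measured compounds differed there and nowhere else. It shows that the hydrogen on this nitrogen is not needed for the read-out in this pair, and that a group of this size, holding both a carbonyl and a bromine, is compatible with a higher number. No measurement at hand accounts for the rise.

The compounds shown leave open whether the gain comes from the carbonyl or from the bromine, a question that a plain acetyl group, or an amine in place of the bromine, could help to separate. A longer chain on the carbonyl could show whether the length of the entering group matters, and other doses could show whether the step holds beyond this single dose.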